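This account rests on a few compounds, and the source may have more. Where it says the series, first, only, none or still open, it means among the compounds named here.

Measured so far in a functional assay on A549 cells (Homo sapiens) for inhibition, read by MTT assay, with a stated time of 24 h; on this read-out lower numbers stand for stronger inhibition and higher numbers for weaker inhibition:
- compound 1 `CCOC(=O)C1=Cc2ccccc2OC1(OCc1cn(CC(=O)Nc2cccc(Cl)c2)nn1)C(F)(F)F`: 12800 nM
- compound 2 `CCOC(=O)C1=Cc2ccccc2OC1(OCc1cn(CC(=O)Nc2ccc(C)cc2)nn1)C(F)(F)F`: 54300 nM
- compound 3 `CCOC(=O)C1=Cc2ccccc2OC1(OCc1cn(-c2cccc(C(F)(F)F)c2)nn1)C(F)(F)F`: > 150000 nM

Going by the values given here, for compound 3 the value is a limit of the assay and not a number, as the limit of > 150000 nM in this assay, at which 1 of the 3 values shown sits, records; it is the only one of the three values that sits there. Compound 4 `CCOC(=O)C1=Cc2ccccc2OC1(OCc1cn(-c2ccc(C)cc2)nn1)C(F)(F)F` is the unmeasured partner: 4-methylphenyl in place of 3-(trifluoromethyl)phenyl on an aromatic nitrogen.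

Among the compounds with values here, no measured step changes the group on the aromatic nitrogen while a direct aryl stays in place, so the step is not covered directly. The nearest evidence is that both carbamoylmethyl arms beat the direct aryl: an at least 11-fold higher number from compound 1 to compound 3 (1.06 log units; beyond the scatter) and an at least 2.7-fold higher number from compound 2 to compound 3 (0.44 log units; beyond the scatter). Within the amide series, the 4-methylphenyl was the weaker partner, a 4.2-fold higher number from compound 1 to compound 2 (0.63 log units; beyond the scatter), but that change sits on an amide-type nitrogen, not on the aromatic nitrogen, and is taken as weak guidance only.

Compound 4 keeps a direct aryl on the aromatic nitrogen, and its value in this assay is expected to stay near the limit, with a step that the limit leaves unreadable from compound 3 to compound 4 as the estimated step. The estimate for compound 4 is 200000 nM, within 70000 nM to 600000 nM, with a substantial chance that only a limit is reported again.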

Compound 4, half-maximal inhibitory concentration: 19700 nM
For compound 4 the middle estimate is 10-fold (1.01 log units) above the measured one; the whole stated range lies above it.
By their numbers in this assay, from the lowest: compounds 1 and 4 (each within the scatter of the next); then compound 2. At a limit, above all of these: compound 3.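

In this assay, a direct aryl on the aromatic nitrogen does not by itself lose the activity, since 4-methylphenyl in place of 3-(trifluoromethyl)phenyl gives an at least 7.6-fold lower number from compound 3 to compound 4 (0.88 log units; beyond the scatter). The value of compound 3 is a limit and not a number: the limit of > 150000 nM in this assay, at which 1 of the 4 values shown sits. The earlier advantage of the carbamoylmethyl arms over the direct aryl therefore holds only against compound 3, as removing the arm gives a 2.8-fold lower number from compound 2 to compound 4 (0.44 log units; beyond the scatter), and a 1.5-fold higher number from compound 1 to compound 4 (0.19 log units; within the scatter) shows no separation between those two.

Compound 3 and compound 4 differ in both the substituent and its place on the ring, and the compounds shown do not separate these two changes. Also open, as far as these compounds go, is how a plain phenyl, or an aryl carrying an amine or a carboxylic acid, reads on the aromatic nitrogen in this assay.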